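Chain Extension on a Shared Core: Cytotoxicity Stays at the Limit

This account rests on a few compounds, and the source may have more. Where it says the series, first, only, none or still open, it means among the compounds named here.

Of the compounds shown here, three have been measured in an ADME assay on L929 cells (Mus musculus) for cytotoxicity, read by resazurin assay, with a stated time of 72 h; a lower number here means a stronger inhibitor, a higher number a weaker inhibitor.
Compound 1 `CCCNC(=O)c1cccn1-c1ccc2c(c1)B(O)OC2` gives > 10 ug/mL, a limit of the assay rather than a number.
Compound 2 `CNC(=O)c1cccn1-c1ccc2c(c1)B(O)OC2` gives > 10 ug/mL, also a limit.
Compound 3 `CCCC(=O)c1ccn(-c2ccc3c(c2)B(O)OC3)c1` gives > 10 ug/mL, again a limit.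

Compound 1 differs from compound 2 by ethyl in place of hydrogen on a saturated chain carbon bound to an amide-type nitrogen. The step that the two limits leave unreadable from compound 2 to compound 1 cannot be read because both values sit at the limit of > 10 ug/mL in this assay, at which 3 of the 3 values shown sit.

Compound 4 `CCCCCC(=O)c1ccn(-c2ccc3c(c2)B(O)OC3)c1` is not yet measured. It differs from compound 3 by ethyl in place of hydrogen on a saturated chain carbon, three bonds along the chain from a carbonyl carbon, the same kind of change as that from compound 2 to compound 1, though the place differs: there the carbon is bound to an amide-type nitrogen, here it lies three bonds along the chain from a carbonyl carbon. The difference between the core of compound 2 and that of compound 3 is not broken down here.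

For compound 4 the step that the limit leaves unreadable from compound 3 to compound 4 is expected, resting on compound 3 giving > 10 ug/mL and on the earlier step being unreadable. Compound 4 is thus estimated at 20 ug/mL, between 7 ug/mL and 60 ug/mL.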

Compound 4, half-maximal inhibitory concentration: > 10 ug/mL
Compound 4 gave a limit, no number; the forecaster's own chance of this, stated with the estimate: 70%; the middle value is on the limit's open side.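

No new step can be read from compound 3 to compound 4, because both compounds give only a limit: the limit of > 10 ug/mL in this assay, at which 4 of the 4 values shown sit.
The compounds shown leave open whether ethyl in place of hydrogen changes cytotoxicity on either core.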